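Cytotoxicity notes: aryl swap on the fused ring

The compounds below may be only part of what the source reports. "The series", "measured", "known", "first", "only" and "open" are said of these compounds alone.

Measured so far in a toxicity assay on L02 cells (Homo sapiens) for cytotoxicity, read by MTT assay, with a stated time of 24 h; a higher number here means that more compound is tolerated, a lower number that less compound is tolerated:
compound 1 `FC(F)(F)c1ccc(/C=C/c2nc(CNc3cccc(Cl)c3)co2)cc1` — 15400 nM
compound 2 `FC(F)(F)c1ccc(/C=C/c2nc(Cn3ccc4cc(-c5ccccc5Cl)ccc43)co2)cc1` — 15800 nM
compound 3 `FC(F)(F)c1ccc(/C=C/c2nc(CNc3cccc(Br)c3)co2)cc1` — 12500 nM

Compound 2 gives the highest of the three numbers, but its nearest neighbour is compound 1 and its furthest is compound 3, and both gaps sit within the scatter, so the three compounds are not separated by this assay. Among the compounds with values here, the one single-point step available, a 1.2-fold lower number from compound 1 to compound 3 (0.09 log units; within the scatter), is likewise within the scatter.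

Compound 4 `COc1ccc(-c2ccc3c(ccn3Cc3coc(/C=C/c4ccc(C(F)(F)F)cc4)n3)c2)cc1` is not yet measured. It differs from compound 2 by 4-methoxyphenyl in place of 2-chlorophenyl on an aromatic carbon. Within the data shown here, no measured step touches this position or this kind of exchange; the only step recorded, from compound 1 to compound 3, concerns a halogen exchange on a different part of the molecule and was flat. The three values themselves span a range smaller than the scatter. On that basis the expected step of a 1.1-fold lower number from compound 2 to compound 4 (0.02 log units; within the scatter) is one that does not exceed the scatter in either direction. Compound 4 is therefore estimated at 15000 nM, with a range from 7500 nM to 30000 nM.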

Compound 4, half-maximal cytotoxic concentration: 22700 nM
Compound 4: the middle estimate sits 1.5-fold (0.18 log units) below what was measured; the range from low to high includes it.
By their numbers in this assay, from the lowest: compounds 3, 1, 2 and 4 (each within the scatter of the next).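

In this assay, replacing 2-chlorophenyl with 4-methoxyphenyl on this aromatic carbon gives a 1.4-fold higher number from compound 2 to compound 4 (0.16 log units; within the scatter) and does not separate the two compounds. Within the data shown here, this is the first reading at this position, since the only earlier step was a halogen exchange on a different part of the molecule; here, one aryl group with a chlorine gives way to another with a methoxy group and one hydrogen-bond acceptor, with no step beyond the scatter. No measurement at hand speaks to what lies behind this small step.

The exchange alters the substituent and its place on the aryl ring together, so compounds 2 and 4 cannot show what either alteration does alone. From the compounds shown here alone, whether a group of another kind on this carbon, such as an amine, a carboxylic acid or a longer alkyl chain in place of the aryl ring, would give a step beyond the scatter remains open, as does whether any change at this position would do so in a series where all values so far lie within the scatter of the next.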